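The source may report more compounds than this note shows. Statements on the series, on what has been measured and on what is new or still open speak of the compounds shown alone.

In a functional assay on SMMC-7721 cells (Homo sapiens) for cytotoxicity, read by MTT assay, with a stated time of 24 h (on this read-out lower numbers stand for stronger inhibition and higher numbers for weaker inhibition), compound 1 `N#Cc1ccc(S(=O)(=O)N2C/C(=C\c3cccnc3)C(=O)/C(=C/c3ccccc3F)C2)cc1` gives 15400 nM and compound 2 `O=C1/C(=C/c2cccnc2)CN(S(=O)(=O)c2ccc(F)cc2)C/C1=C\c1ccccc1C(F)(F)F` gives 6390 nM. Compound 2 therefore holds the lower of the two numbers, with a gap beyond the scatter. Compound 3 `N#Cc1ccc(S(=O)(=O)N2C/C(=C\c3cccnc3)C(=O)/C(=C/c3ccccc3C(F)(F)F)C2)cc1` departs from compound 2 in one place, on an aromatic carbon of a six-membered aromatic ring of carbon only, para to a large group: cyano in place of fluoro on an aromatic carbon. This puts cyano in place of fluoro, turning 4-fluorophenyl to 4-cyanophenyl. Among the measured compounds shown here, no measured step isolates this change, so the expectation is tentative. A modest move toward a higher number in this assay is expected, only slightly beyond the scatter. That direction rests on compound 1, which also carries the 4-cyanophenyl group, at 15400 nM. The estimated step is a 1.4-fold higher number from compound 2 to compound 3 (0.15 log units; within the scatter). For compound 3 the estimated value is 9000 nM, with an expected range from 4000 nM to 20000 nM.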

Compound 3, half-maximal inhibitory concentration: 9650 nM
Compound 3: middle estimate off by 1.1-fold (0.03 log units), on the low side; the range from low to high includes it.
By their numbers in this assay, from the lowest: compounds 2, 3 and 1 (each within the scatter of the next, the first and the last beyond it).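

Of the changes in the sulfonyl part, cyano in place of fluoro in this assay gives a 1.5-fold higher number from compound 2 to compound 3 (0.18 log units; within the scatter) and so, at this position, does not separate the 4-cyanophenyl group from the 4-fluorophenyl group. The second single change, from fluoro to trifluoromethyl, gives a 1.6-fold lower number from compound 1 to compound 3 (0.20 log units; within the scatter) and also stays within the scatter, so neither swap on its own yields a clear difference in this read-out. Nothing measured here accounts for the size of either step.

The compounds shown leave open whether an amine or a carboxylic acid on this same aromatic carbon, para to the large group, would give a step beyond the scatter. They also leave open how a change to the shared core would read, since all three compounds keep it.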